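The source may hold more compounds than are shown below. What is called first, only, known or untested is meant among the compounds shown, and "the series" means these compounds.

Two compounds that share a central core and differ only in the ring fused to it have been tested. Compound 1 `COc1ccc2nc(Cn3cnc4ccccc43)cc(=O)n2c1` gives in an ADME assay on microsomes from liver (Homo sapiens) for metabolic stability (a lower number here means slower removal, a higher number faster removal of the compound), a value of 8 mL.min-1.g-1. Compound 2 `O=c1cc(Cn2cnc3ccccc32)nc2sccn12` gives in this assay a value of 8 mL.min-1.g-1, level with compound 1 at the digits shown, so the two compounds sit together within the scatter of repeated runs and neither can be called more stable than the other.

Compound 3 `O=c1cc(Cn2cnc3ccccc32)nc2scc(-c3ccccc3)n12` has not yet been run in this assay. It differs from compound 2 in one place: phenyl in place of hydrogen on an aromatic carbon. Within the data shown here, no step between measured compounds is available as a guide, so the starting point is simply the reading of compound 2, 8 mL.min-1.g-1, and the question is whether phenyl in place of hydrogen moves the number beyond the scatter.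

The expectation is a moderate rise rather than no change. Compound 3 is expected to give about 18 mL.min-1.g-1 in this assay. The range for compound 3 is estimated from 7 mL.min-1.g-1 to 45 mL.min-1.g-1. The expected step is a 2.3-fold higher number from compound 2 to compound 3 (0.35 log units; beyond the scatter).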

Compound 3, intrinsic clearance in microsomes: 8 mL.min-1.g-1
For compound 3 the middle estimate is 2.3-fold (0.35 log units) above the measured one; the measured number falls inside the stated range.
By their numbers in this assay, from the lowest: compounds 1, 2 and 3 (each within the scatter of the next).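

The new step shows that this position, an aromatic carbon of the five-membered aromatic ring with 1 nitrogen and 1 sulfur, can carry a whole phenyl ring in place of hydrogen without moving the reading in this assay: the result is no change at the digits printed from compound 2 to compound 3 (within the scatter). The earlier pair differed only in the ring fused to the shared core, so it said nothing about adding a group at this carbon; here 6 heavy atoms enter, and the number still stays within the usual scatter of repeated runs. No measurement at hand bears on why the reading holds.

As far as these compounds go, what remains open is whether this tolerance belongs to phenyl alone or to the position as a whole, since a different group on the same carbon, such as an amine, a carboxylic acid or a longer chain, could give either a similar or a clearly different number. A single step also cannot show whether phenyl would leave the reading just as undisturbed on the core of compound 1, where the fused ring is a different one.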